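Amine Swap on the Shared Core and Cytotoxicity

The source may report more compounds than this note shows. Statements on the series, on what has been measured and on what is new or still open speak of the compounds shown alone.

Compound 1 `Cc1nc(NC(C)(C)C)nc(N[C@@H]2C[C@H](CO)[C@@H](O)[C@H]2O)c1-c1nc2ccccc2s1` gives 12000 nM in an ADME assay on cells (Homo sapiens) for cytotoxicity, read by polymerase chain reaction, with a stated time of 3 days; on this read-out lower numbers stand for higher toxicity in this test and higher numbers for lower toxicity in this test.
Compound 2 `Cc1nc(N(C)C)nc(N[C@@H]2C[C@H](CO)[C@@H](O)[C@H]2O)c1-c1nc2ccccc2s1` gives 18000 nM in this assay.
Compound 3 `CCc1nc(N(C)C)nc(N[C@@H]2C[C@H](CO)[C@@H](O)[C@H]2O)c1-c1nc2ccccc2s1` is reported in this assay only as a limit, > 25000 nM.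

Of the two numbers that are not limits, compound 2 holds the higher one, and its nearest neighbour is compound 1: the change of dimethylamino in place of tert-butylamino on an aromatic carbon gave a 1.5-fold higher number from compound 1 to compound 2 (0.18 log units; within the scatter). The further change of methyl in place of hydrogen on the saturated chain carbon bound to an aromatic carbon gave an at least 1.3-fold higher number from compound 2 to compound 3 (0.14 log units; that floor lies within the scatter), where the floor of that step is set by the limit of > 25000 nM in this assay, at which 1 of the 3 values shown sits.

Compound 4 `Cc1nc(NCCCC(F)(F)F)nc(N[C@@H]2C[C@H](CO)[C@@H](O)[C@H]2O)c1-c1nc2ccccc2s1` has not been measured. It differs from compound 2 by (4,4,4-trifluorobutyl)amino in place of dimethylamino on an aromatic carbon. Within the data shown here, the steps that bear on it are the two amine and chain changes already seen, each of which stayed within the scatter, one of them only as a floor. On that basis the change from compound 2 to compound 4 is expected to produce no step beyond the scatter in this assay, in either direction, and the estimated step is a 1.1-fold lower number from compound 2 to compound 4 (0.05 log units; within the scatter). For compound 4 the estimate is therefore 16000 nM, with a range from 7000 nM to 30000 nM.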

Compound 4, half-maximal cytotoxic concentration: 3000 nM
The estimate for compound 4 lay 5.3-fold (0.73 log units) above the measured number; measured number below the stated range.
By their numbers in this assay, from the lowest: compound 4; then compounds 1 and 2 (each within the scatter of the next). At a limit, above all of these: compound 3.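

Among these compounds, at this position, on an aromatic carbon between two ring nitrogen atoms, the amine does matter in this assay: (4,4,4-trifluorobutyl)amino in place of dimethylamino gave a 6.0-fold lower number from compound 2 to compound 4 (0.78 log units; beyond the scatter), the first change here to go beyond the scatter, and it moved toward higher toxicity in this test. The comparison with the other amine points the same way, as 4,4,4-trifluorobutyl in place of tert-butyl on the nitrogen gave a 4.0-fold lower number from compound 1 to compound 4 (0.60 log units; beyond the scatter), so compound 4 stands apart from both compound 1 and compound 2, which remain within the scatter of each other. No measurement shown here accounts for this shift, so the part of the chain responsible cannot be named.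

The compounds shown leave open whether the fluorine atoms or the length of the chain carry this step, which a plain butylamino group or a shorter 3,3,3-trifluoropropylamino group on the same carbon would help to separate. Also open, going by these compounds, is how the (4,4,4-trifluorobutyl)amino group would behave on the ethyl-bearing core of compound 3, whose own reading is only a limit, > 25000 nM.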